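Swapping Acetoxy for Acetamido on the Long Chain

The source may report more compounds than this note shows. Statements on the series, on what has been measured and on what is new or still open speak of the compounds shown alone.

In a functional assay on MOLT-4F cells (Homo sapiens) for antiproliferative activity (on this read-out higher numbers stand for weaker inhibition of growth and lower numbers for stronger inhibition of growth), compound 1 (`COC(=O)CCCCCCCCCCCCCC/C=C1\CC(CO)(COC(=O)C(C)(C)C)OC1=O`) gives a limit (> 10 ug/mL), not a number. Among the compounds with values here, compound 2 (`CC(=O)OCCCCCCCCCCCCCCC/C=C1\CC(CO)(COC(=O)C(C)(C)C)OC1=O`) gives the only actual number (1.55 ug/mL). Compound 3 (`CC(=O)NCCCCCCCCCCCCCCC/C=C1\CC(CO)(COC(=O)C(C)(C)C)OC1=O`) differs from compound 2 in one group (acetamido in place of acetoxy on a saturated chain carbon, ten or more bonds along the chain from a double-bonded chain carbon). Within the data shown here, the one measured step (an at least 6.4-fold lower number from compound 1 to compound 2 (0.80 log units; beyond the scatter)) touched the same place on the chain and shows that a swap there can matter. That step is a single guide, so only a modest move toward weaker inhibition of growth is expected for compound 3 (a 1.9-fold higher number from compound 2 to compound 3 (0.29 log units; within the scatter)). The estimated value for compound 3 is 3 ug/mL (range 1 ug/mL to 10 ug/mL).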

Compound 3, concentration for 50% growth inhibition: 6.35 ug/mL
Compound 3: the middle estimate sits 2.1-fold (0.33 log units) below what was measured, within the range that was stated.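

In this assay, the end of the chain responds even to an exchange of equal heavy-atom count: acetamido in place of acetoxy gives a 4.1-fold higher number from compound 2 to compound 3 (0.61 log units; beyond the scatter). Acetamido carries one hydrogen-bond donor where acetoxy has none, yet this single step cannot show whether that donor is responsible. The other step, an at least 1.5-fold lower number from compound 1 to compound 3 (0.19 log units; that floor lies within the scatter), does not clearly separate compound 3 from compound 1, whose entry is a limit and not a number: the limit of > 10 ug/mL in this assay, at which 1 of the 3 values shown sits.

As far as these compounds go, whether a free amine or a hydroxyl at the chain end, or a longer chain, would give a lower number than compound 2 stays open.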